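The compounds below may be only part of what the source reports. "The series", "measured", "known", "first", "only" and "open" are said of these compounds alone.

In an in vitro ADME assay on microsomes from Gut (Homo sapiens) for metabolic stability, using NADPH (a lower number here means slower removal, a higher number faster removal of the compound), compound 1 (`COc1ccc(OC(F)(F)F)cc1Cn1c(C(=O)NCC(C)(C)CO)cc2cc(C#N)ccc21`) gives < 6 mL.min-1.g-1, which is a limit and not a number. Compound 2 (`CCOc1ccc(OC(F)(F)F)cc1Cn1c(C(=O)NCC(C)(C)CO)cc2cc(C#N)ccc21`) gives < 6 mL.min-1.g-1, also a limit. Compound 3 (`COc1ccc(Cl)cc1Cn1c(C(=O)NCC(C)(C)CO)cc2cc(C#N)ccc21`) gives < 6 mL.min-1.g-1, again a limit. The whole series known so far therefore stands at one place, (the limit of < 6 mL.min-1.g-1 in this assay, at which 3 of the 3 values shown sit), and compound 1 has no readable position within it.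

Compound 4 (`COc1ccc(OC(F)(F)F)cc1Cn1c(C(=O)NCC2(CO)CC2)cc2cc(C#N)ccc21`) differs from compound 1 in one place: 1-(hydroxymethyl)cyclopropyl in place of 1-(hydroxymethyl)-1-methylethyl on a saturated chain carbon bound to an amide-type nitrogen. In short, 1-(hydroxymethyl)cyclopropyl stands in place of 1-(hydroxymethyl)-1-methylethyl, on a saturated chain carbon bound to an amide-type nitrogen.

Two measured steps are available, a step that the two limits leave unreadable from compound 1 to compound 2 and a step that the two limits leave unreadable from compound 1 to compound 3. Neither falls at the place where compound 4 differs, and neither has a size that can be read, so they offer no size to carry over. The only anchor for the expectation is compound 1, with its limit of < 6 mL.min-1.g-1. The step expected in this assay is a step that the limit leaves unreadable from compound 1 to compound 4, with no shift beyond the scatter in either direction. The estimate for compound 4 is 5 mL.min-1.g-1, with an expected range from 3 mL.min-1.g-1 to 9 mL.min-1.g-1, and the result may well be reported only as a limit.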

Compound 4, intrinsic clearance in microsomes: < 6 mL.min-1.g-1
Compound 4 was reported as a limit; the forecaster's own chance of this, stated with the estimate: 75%; the middle value does not contradict the limit.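

In this assay, compound 4 is reported only as a limit, as compound 1 is, so no step can be read between compound 1 and compound 4. The compounds shown leave open how fast each is actually removed and whether 1-(hydroxymethyl)cyclopropyl in place of 1-(hydroxymethyl)-1-methylethyl makes any difference, with all of them at one place: the limit of < 6 mL.min-1.g-1 in this assay, at which 4 of the 4 values shown sit.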